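A few compounds are considered here, and "the series" means these few. Any claim that something is new, unique, unknown or untested is made for them only; others in the source may bear on it.

Compound 1, whose structure is `COc1cc(-c2nnc3n2NC(c2ccco2)C(C(=O)c2ccccc2F)S3)cc(OC)c1OC`, is the starting point of this comparison. In a functional assay on PC-3 cells (Homo sapiens) for cytotoxicity, read by MTT assay, with a stated time of 48 h (on this read-out lower numbers stand for stronger inhibition and higher numbers for weaker inhibition), compound 1 gives > 100000 nM, which is a limit of the assay and not a number. Compound 2, with structure `COc1cc(-c2nnc3n2NC(c2ccco2)C(C(=O)c2ccc(O)cc2)S3)cc(OC)c1OC`, carries 4-hydroxyphenyl in place of 2-fluorophenyl on a carbonyl carbon; in this assay compound 2 gives 38300 nM. For the measured compounds named here, the one measured step, an at least 2.6-fold lower number from compound 1 to compound 2 (0.41 log units; beyond the scatter), is itself bounded by the fact that compound 1 sits at the limit of > 100000 nM in this assay, at which 1 of the 2 values shown sits.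

Compound 3, whose structure is `COc1cc(-c2nnc3n2NC(c2ccco2)C(C(=O)c2cccc(Br)c2)S3)cc(OC)c1OC`, differs from compound 1 by 3-bromophenyl in place of 2-fluorophenyl on a carbonyl carbon. Going by the values given here, no measured step covers a 3-bromophenyl group; the only comparison that bears on a change at this carbonyl carbon is an at least 2.6-fold lower number from compound 1 to compound 2 (0.41 log units; beyond the scatter), and it concerns a different group. The shared core has so far given only weak inhibition or a limit in this assay. Compound 3 is therefore expected to show a step of an at least 1.4-fold lower number from compound 1 to compound 3 (0.15 log units; that floor lies within the scatter), that is, little or no movement beyond the scatter. The estimate for compound 3 in this assay is 70000 nM, with a range from 20000 nM to 150000 nM.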

Compound 3, half-maximal inhibitory concentration: 63900 nM
Estimate against measurement, compound 3: 1.1-fold (0.04 log units) above; the range from low to high includes it.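

The move to 3-bromophenyl on a carbonyl carbon gives an at least 1.5-fold lower number from compound 1 to compound 3 (0.19 log units; that floor lies within the scatter), so although a number now stands where the 2-fluorophenyl group gave none, this change cannot be called a real gain in this assay. The other comparison, a 1.7-fold higher number from compound 2 to compound 3 (0.22 log units; within the scatter), does not separate 3-bromophenyl from 4-hydroxyphenyl, which shows that a hydroxyl group on the phenyl ring is not needed for a number to be read at this position. Compound 1 remains a limit and not a number, so the distance of the 2-fluorophenyl group from the other two groups is bounded from one side only: the limit of > 100000 nM in this assay, at which 1 of the 3 values shown sits.

On these data alone, all three compounds carry a substituted phenyl ring on this carbonyl carbon, so it remains open whether an amine, a carboxylic acid or a longer chain in place of that ring would move the number beyond the scatter. As far as these compounds go, it is equally open whether a chlorine or a nitrile in place of the bromine would matter, and whether any change to the shared core outside this carbonyl carbon would shift the read-out at all.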